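The source may hold more compounds than are shown below. What is called first, only, known or untested is meant among the compounds shown, and "the series" means these compounds.

In an ADME assay on BaF3 cells (Mus musculus) for inhibition, read by CellTiter-Glo, with a stated time of 72 h (a lower number here means a stronger inhibitor of growth, a higher number a weaker inhibitor of growth), compound 2 `Cc1ccc(Nc2ncc3c(n2)N(Cc2ccccc2)C(=O)N(c2cc(NC(=O)c4ccc(C)c(C(F)(F)F)c4)ccc2C)C3)cn1` gives > 5000 nM. That figure is a limit of the assay and not a number, so compound 2 stands at the limit of > 5000 nM in this assay, at which 1 of the 2 values shown sits. Among the compounds with values here, the only other measured compound, compound 1 `Cc1ccc(Nc2ncc3c(n2)N(C)C(=O)N(c2cc(NC(=O)c4ccc(C)c(C(F)(F)F)c4)ccc2C)C3)cn1`, gives 870 nM in this assay. Compound 3 `Cc1ccc(Nc2ncc3c(n2)N(C2CCCCC2)C(=O)N(c2cc(NC(=O)c4ccc(C)c(C(F)(F)F)c4)ccc2C)C3)cn1` has not yet been measured. It differs from compound 2 in one place: cyclohexyl in place of benzyl on an amide-type nitrogen in a ring. Cyclohexyl stands in place of benzyl on an amide-type nitrogen in a ring, so a non-aromatic ring of carbon only replaces an aromatic one.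

Within the data shown here, the one measured step that bears on this is an at least 5.7-fold higher number from compound 1 to compound 2 (0.75 log units; beyond the scatter), a change beyond the scatter at that same nitrogen. The number rose once benzyl stood there, and cyclohexyl is likewise a six-membered ring of carbon only. Compound 3 is therefore expected to stay near the limit rather than return towards the value of compound 1, with no step beyond the scatter in this assay. The estimated change is an at least 1.2-fold lower number from compound 2 to compound 3 (0.09 log units; that floor lies within the scatter), and it remains uncertain since it starts from a limit. For compound 3 the expected value is 4000 nM, with an estimated range of 1500 nM to 10000 nM.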

Compound 3, concentration for 50% growth inhibition: > 5000 nM
Compound 3 gave a limit, no number; the forecaster's own chance of this, stated with the estimate: 50%; middle value at least 1.2-fold (0.09 log units) from the limit.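

In this assay, cyclohexyl in place of methyl on the amide-type nitrogen in a ring gives an at least 5.7-fold higher number from compound 1 to compound 3 (0.75 log units; beyond the scatter), a rise in the number beyond the scatter. Until now, only benzyl had been seen to raise the number at this nitrogen; compound 3 shows that the same holds for a six-membered non-aromatic ring of carbon only, so an aromatic ring is not required for this rise, and neither compound 2 nor compound 3 goes against that. Compound 3 gives a limit of the assay and not a number, as does compound 2, and the step between these two compounds cannot be read, so the data do not rank benzyl against cyclohexyl: the limit of > 5000 nM in this assay, at which 2 of the 3 values shown sit.

What remains open is how large a group this nitrogen tolerates before the number rises, since nothing shown lies between methyl and the two ring groups, and a short chain such as ethyl or isopropyl would address that. As far as these compounds go, it is also open whether a ring or chain carrying other atoms, such as a piperidine, a tetrahydropyran or a hydroxyethyl chain, would behave as cyclohexyl does.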